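What 4-fluorophenyl may do in place of 1-phenylethyl

A few compounds are considered here, and "the series" means these few. Any claim that something is new, unique, unknown or untested is made for them only; others in the source may bear on it.

Two related compounds have been measured in a functional assay on K562 cells (Homo sapiens) for inhibition, read by luminescence, with a stated time of 72 h, tested at 5 uM; on this read-out higher numbers stand for more inhibition of growth at the one concentration tested and lower numbers for less inhibition of growth. There, compound 1 `C=CS(=O)(=O)NC/C=C/c1cc(OC)cc(O)c1C(=O)OCc1ccc(Br)cc1` gives 38.4%, and compound 2 `C=CS(=O)(=O)NC/C=C/c1cc(OC)cc(O)c1C(=O)OCC(C)c1ccccc1` gives 16.7%, the lower of the two numbers. The next compound to consider is compound 3 `C=CS(=O)(=O)NC/C=C/c1cc(OC)cc(O)c1C(=O)OCc1ccc(F)cc1`, and its structural change is 4-fluorophenyl in place of 1-phenylethyl on a saturated chain carbon bound to an oxygen next to a carbonyl group. Going by the values given here, only one measured step bears on this: a number 21.7 percentage points lower from compound 1 to compound 2 (beyond the scatter), in which 1-phenylethyl took the place of 4-bromophenyl. The new change also removes 1-phenylethyl, so a rise in the same read-out is expected. Among the compounds with values here, that rise may be somewhat smaller, since no measurement yet shows how 4-fluorophenyl compares with 4-bromophenyl in this setting. The expected change is a number 13.3 percentage points higher from compound 2 to compound 3 (beyond the scatter). The estimate for compound 3 is 30%, with an expected range of 16% to 45%.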

Compound 3, percent growth inhibition at one concentration: 52%
The estimate for compound 3 lay 22 percentage points below the measured number, outside the stated range (above it).
By their numbers in this assay, from the lowest: compound 2; then compound 1; then compound 3.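

In this assay, this position proves far more responsive than the first pair suggested, with a step of a number 35.3 percentage points higher from compound 2 to compound 3 (beyond the scatter) for 4-fluorophenyl in place of 1-phenylethyl. The halogen alone also matters here: fluoro in place of bromo on an aromatic carbon gives a number 13.6 percentage points higher from compound 1 to compound 3 (beyond the scatter) and places compound 3 highest of the three, with its steps to both others beyond the scatter. Nothing measured here explains why the fluoro compound reads higher.

From the compounds shown here alone, the step from compound 2 changes both the chain and the halogen, so their separate shares remain unknown, and a 4-fluorophenyl group on the 1-phenylethyl-type chain would be needed to divide them. Going by these compounds, it also remains open whether an unsubstituted phenyl, 4-chlorophenyl or 4-methoxyphenyl would fit the same trend.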